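Amide series: trimming the aryl cap on the amide nitrogen

A few compounds are considered here, and "the series" means these few. Any claim that something is new, unique, unknown or untested is made for them only; others in the source may bear on it.

Measured so far in a functional assay on HCT-116 cells (Homo sapiens) for inhibition, read by colorimetric assay, with a stated time of 3 days; on this read-out lower numbers stand for stronger inhibition and higher numbers for weaker inhibition:
compound 1 `O=C(CCCCCCNC(=O)C(O)(O)C(F)(F)F)Nc1nccs1`: 10800 nM
compound 2 `CC(=O)c1ccc(NC(=O)CCCCCCNC(=O)C(O)(O)C(F)(F)F)cc1`: 12100 nM
compound 3 `Cc1ccc(S(=O)(=O)Nc2ccc(NC(=O)CCCCCCNC(=O)C(O)(O)C(F)(F)F)cc2)cc1`: 17200 nM

Compound 3 gives the highest number of the three, yet both its neighbours lie within the scatter of it. Compound 4 `O=C(CCCCCCNC(=O)C(O)(O)C(F)(F)F)Nc1ccccc1` differs from compound 3 by hydrogen in place of ((4-methylphenyl)sulfonyl)amino on an aromatic carbon. Within the data shown here, the steps that bear on this cap are a 1.1-fold higher number from compound 1 to compound 2 (0.05 log units; within the scatter) and a 1.4-fold higher number from compound 2 to compound 3 (0.15 log units; within the scatter), both within the scatter, so changes to the cap have so far left this assay essentially unmoved. No step beyond the scatter is therefore expected for compound 4 in either direction. Compound 4 is expected to give about 13000 nM, with a range from 6000 nM to 28000 nM. The expected step is a 1.3-fold lower number from compound 3 to compound 4 (0.12 log units; within the scatter).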

Compound 4, half-maximal inhibitory concentration: 9140 nM
Estimate against measurement, compound 4: 1.4-fold (0.15 log units) above, and the stated range covers the measured number.
By their numbers in this assay, from the lowest: compounds 4, 1, 2 and 3 (each within the scatter of the next).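

In this assay the step of a 1.9-fold lower number from compound 3 to compound 4 (0.27 log units; within the scatter) lies within the scatter, so this aromatic carbon tolerates the loss of the whole ((4-methylphenyl)sulfonyl)amino group, all 11 heavy atoms of it, without a step beyond the scatter. Hydrogen in place of acetyl gives a 1.3-fold lower number from compound 2 to compound 4 (0.12 log units; within the scatter) and phenyl in place of 1,3-thiazol-2-yl gives a 1.2-fold lower number from compound 1 to compound 4 (0.07 log units; within the scatter) and both also lie within the scatter, so even the unsubstituted phenyl cap does not stand apart. Nothing available explains this flat response.

From the compounds shown here alone, whether an amine or a carboxylic acid on this aromatic carbon would give a step beyond the scatter stays open. So does the effect of a longer chain in the shared core.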